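Methyl to Trifluoromethyl on the Shared Core

The compounds below may be only part of what the source reports. "The series", "measured", "known", "first", "only" and "open" are said of these compounds alone.

Of the compounds shown here, three built on the shared core have been measured so far in an assay on isolated protein for inhibition of transient receptor potential cation channel subfamily V member 1 (Homo sapiens), read by calcium flux; a lower number here means a stronger inhibitor, a higher number a weaker inhibitor. Compound 1 `O=C(Nc1cccc2[nH]ncc12)NC1CCc2ncccc21` gives 5820 nM. Compound 3 `O=C(Nc1cccc2[nH]ncc12)NC1CCc2cccnc21` gives 1350 nM. Compound 2 `Cc1ccc2c(c1)CCC2NC(=O)Nc1cccc2[nH]ncc12` gives 11 nM, the lowest of the three numbers; compound 3 stands nearest at a higher number and compound 1 furthest, and both gaps lie beyond the scatter. No pair among these three differs in only one place, so the measured set offers no single-change step to lean on.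

The next compound, compound 4 `O=C(Nc1cccc2[nH]ncc12)NC1CCc2cc(C(F)(F)F)ccc21`, differs from compound 2 in one place: trifluoromethyl in place of methyl on an aromatic carbon. The group that leaves and the group that enters both bring no hydrogen-bond donor, no hydrogen-bond acceptor and no net charge, and the place on the ring is unchanged. Nothing measured here shows how this exchange behaves on this core, so the expectation rests on compound 2 alone. The step from compound 2 to compound 4 is expected to be small, a 1.4-fold higher number from compound 2 to compound 4 (0.13 log units; within the scatter), and not clearly beyond the scatter. Compound 4 is therefore estimated at 15 nM in this assay, with a range from 4 nM to 60 nM.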

Compound 4, half-maximal inhibitory concentration: 3 nM
Compound 4: middle estimate off by 5.0-fold (0.70 log units), on the high side; the measured number lies below the stated range.
By their numbers in this assay, from the lowest: compound 4; then compound 2; then compound 3; then compound 1.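

In this assay, within the data shown here, the exchange of methyl for trifluoromethyl on this aromatic carbon gives a modest step that lies beyond the scatter (a 3.7-fold lower number from compound 2 to compound 4 (0.56 log units; beyond the scatter)), so this place on the ring does respond to the group it carries, something the earlier compounds could not show because no pair among them differed in only one place. The entering group brings more heavy atoms but no hydrogen-bond donor, no hydrogen-bond acceptor and no net charge, so a change in the number at this place does not require any of these three features to be added. No measured property of either group bears on this step, which therefore stands as an observation without an explanation.

Going by these compounds, whether the number keeps falling, holds or rises with other groups on this aromatic carbon, such as a chlorine atom, a methoxy group, an amine, a carboxylic acid or a longer chain, remains open. Also open, on these data alone, is whether the same exchange gives a step of similar size at another place on the ring, or on the cores of compound 1 and compound 3, which carry neither group.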